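The source may report more compounds than this note shows. Statements on the series, on what has been measured and on what is new or still open speak of the compounds shown alone.

Two compounds share one core and differ only in the group hanging from the benzyl end. Compound 1 `COc1cccc(OC)c1OCCNCCOc1ccccc1OCc1cccc(Cl)c1` gives 0.251 nM in an assay on CHO cells for displacement of a labelled ligand from Alpha-1A adrenergic receptor (Homo sapiens); on this read-out lower numbers stand for stronger inhibition and higher numbers for weaker inhibition. Compound 2 `COc1cccc(OC)c1OCCNCCOc1ccccc1OCc1cccc(C)c1`, which carries methyl in place of chloro on an aromatic carbon, gives 0.398 nM in this assay; the step of a 1.6-fold higher number from compound 1 to compound 2 (0.20 log units; within the scatter) leaves the two compounds indistinguishable, so compound 2 stands alongside compound 1 with a gap that lies within the scatter. Compound 3 `COc1cccc(OC)c1OCCNCCOc1ccccc1OCc1ccccc1[N+](=O)[O-]` carries the change (2-nitrophenyl in place of 3-methylphenyl on a saturated chain carbon bound to an oxygen on an aromatic ring). Among the compounds with values here, the only measured step, a 1.6-fold higher number from compound 1 to compound 2 (0.20 log units; within the scatter), exchanged one group for another on an aromatic carbon and moved nothing beyond the scatter; it does not cover a nitro group or the change from 3-methylphenyl to 2-nitrophenyl, so the expectation for this assay rests on thin ground. The expected step of a 1.5-fold higher number from compound 2 to compound 3 (0.18 log units; within the scatter) is therefore small, leaning slightly toward a higher number. Compound 3 is estimated at 0.6 nM, within a range from 0.2 nM to 2 nM.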

Compound 3, inhibition constant: 7.94 nM
Beside the measured number, compound 3's estimate is 13-fold (1.12 log units) below it; the whole stated range lies below it.
By their numbers in this assay, from the lowest: compounds 1 and 2 (each within the scatter of the next); then compound 3.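

The benzyl end of the molecule turns out not to accept every change equally: in this assay, moving to the 2-nitrobenzyl group gives a 20-fold higher number from compound 2 to compound 3 (1.30 log units; beyond the scatter), and the comparison with the chloro analogue gives a 32-fold higher number from compound 1 to compound 3 (1.50 log units; beyond the scatter). Exchanging chloro for methyl had shown no difference beyond the scatter, so these three compounds are the first sign that the group at this position can matter a great deal for this read-out. Nothing available here explains the loss.

This single change replaces methyl with nitro and also alters the ring place, as the names 3-methylphenyl and 2-nitrophenyl show, so the two contributions cannot be separated. On these data alone, how a nitrile or an amine would behave on this benzyl ring remains open.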